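The source may hold more compounds than are shown below. What is called first, only, known or untested is meant among the compounds shown, and "the series" means these compounds.

Compound 1, `CCn1c(C(=O)N[C@@H](CC(=O)OC)C(=O)OC)ccc1C(CC)(CC)c1ccc(OCS(=O)(=O)c2ccccc2)c(C)c1`: in a functional assay on BXPC-3 cells (Homo sapiens) for antiproliferative activity, read by MTT assay, with a stated time of 24 h (a lower number here means a stronger inhibitor, a higher number a weaker inhibitor), compound 1 gives > 50000 nM, which is a limit of the assay.
Compound 2, `CCn1c(C(=O)NC2(CO)CC2)ccc1C(CC)(CC)c1ccc(OCS(=O)(=O)c2ccccc2)c(C)c1`: in this assay compound 2 gives 45400 nM.

Within the data shown here, compound 2 holds the only actual number; the other value shown is the limit (the limit of > 50000 nM in this assay, at which 1 of the 2 values shown sits), at which compound 1 sits. Among the measured compounds shown here, the one measured step is an at least 1.1-fold lower number from compound 1 to compound 2 (0.04 log units; that floor lies within the scatter), a change on the amide-type nitrogen that stays within the usual scatter, so the two compounds cannot be told apart on the numbers.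

Compound 3, `CCn1c(C(=O)N[C@H](C)C(=O)O)ccc1C(CC)(CC)c1ccc(OCS(=O)(=O)c2ccccc2)c(C)c1`, has not yet been tested. It differs from compound 2 by 1-carboxyethyl in place of 1-(hydroxymethyl)cyclopropyl on an amide-type nitrogen. For the measured compounds named here, the step from compound 1 to compound 2 bears on it only loosely: it shows that exchanging one group on this amide-type nitrogen for another left the read-out flat, but no measured step introduces a 1-carboxyethyl group. Compound 2 is expected to pass to compound 3 with a step of a 1.1-fold higher number from compound 2 to compound 3 (0.04 log units; within the scatter), not beyond the scatter. The estimate for compound 3 is therefore 50000 nM, with a range from 20000 nM to 120000 nM, and a fair chance that only a limit is reported.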

Compound 3, half-maximal inhibitory concentration: 20100 nM
Compound 3: middle estimate off by 2.5-fold (0.40 log units), on the high side; low and high end bracket the measured number.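

On the amide-type nitrogen, where the earlier step stayed within the scatter, this assay now shows a change that can be read, with 1-carboxyethyl in place of 1-(hydroxymethyl)cyclopropyl: a 2.3-fold lower number from compound 2 to compound 3 (0.35 log units; beyond the scatter). Among these compounds, the same group set against 1,2-bis(methoxycarbonyl)ethyl gives an at least 2.4-fold lower number from compound 1 to compound 3 (0.39 log units; beyond the scatter), which makes compound 3 the one compound of the three with steps to both others printed as beyond the scatter, and shows that the number does respond to what is carried at this position. That second step gives only a floor and not a size, since compound 1 sits at a limit of the assay: the limit of > 50000 nM in this assay, at which 1 of the 3 values shown sits.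

Compound 3 differs from compound 2 at once in its carboxylic acid, in the absence of the three-membered ring and in its defined stereocentre, and no pair shown separates these features. Still open, going by these compounds, is what the mirror-image form of the 1-carboxyethyl group, its methyl ester, a primary amide, an amine or a longer chain ending in a carboxylic acid would give on this nitrogen.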